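The source may report more compounds than this note shows. Statements on the series, on what has been measured and on what is new or still open speak of the compounds shown alone.

Compound 1 `CN1C/C(=C\c2ccc(Br)cc2)C(=O)[C@]2(C1)[C@@H](c1ccc(Br)cc1)CN(C)[C@@]21C(=O)Nc2ccccc21` is the parent of the first pair. In a functional assay on the whole organism (strain Wister albino) for inhibition, with Rattus norvegicus as the target, read by paw edema, with stated times of 1 h and 4 h, at a dose of 50 mg/kg by the intraperitoneal route (a higher number here means more inhibition at the dose given (going by the name of the read-out), a lower number less inhibition), compound 1 gives 118%. Compound 2 `CN1C/C(=C\c2ccc(Br)cc2)C(=O)[C@]2(C1)[C@@H](c1ccc(Br)cc1)CN(C)[C@@]21C(=O)N(C)c2ccccc21` carries the change (methyl in place of hydrogen on an amide-type nitrogen in a ring). In this assay compound 2 gives 82.8%. Among the compounds with values here, the step of a number 35.2 percentage points lower from compound 1 to compound 2 (beyond the scatter) is the only measured instance of this change.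

Compound 3 `Cc1ccc(/C=C2\CN(C)C[C@@]3(C2=O)[C@@H](c2ccc(C)cc2)CN(C)[C@@]32C(=O)Nc3ccccc32)cc1` rests on a different core; how the core of compound 3 differs from the core of compound 1 is not broken down here. In this assay compound 3 gives 89.7%. Against compound 2 this value lies within the usual scatter, so no order between compound 2 and compound 3 is read from it; against compound 1 it is lower by more than the scatter.

Compound 4 `Cc1ccc(/C=C2\CN(C)C[C@@]3(C2=O)[C@@H](c2ccc(C)cc2)CN(C)[C@@]32C(=O)N(C)c3ccccc32)cc1` is not yet measured. It stands to compound 3 as compound 2 stands to compound 1: the change methyl in place of hydrogen on an amide-type nitrogen in a ring is the same change, at the same place, made on the core of compound 3. The expectation for compound 4 therefore rests on a single pair. Within the data shown here, the step of a number 34.7 percentage points lower from compound 3 to compound 4 (beyond the scatter) is expected to be a drop of similar size because a number 35.2 percentage points lower from compound 1 to compound 2 (beyond the scatter) is the only precedent for this change, though a single pair on another core is thin ground. From the compounds shown here alone, compound 4 is thus estimated at 55% in this assay, with a range from 35% to 78%, the width reflecting that the carry-over between cores is untested.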

Compound 4, a percentage reported as inhibition, in the whole organism at one dose (the size of the read-out at that dose, not a potency): 122%
For compound 4 the middle estimate is 67 percentage points below the measured one, and the stated range ends below it.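

In this assay, methyl in place of the amide hydrogen on the core of compound 3 gives a step that is a number 32.3 percentage points higher from compound 3 to compound 4 (beyond the scatter), so the same change at the same place does not carry a fixed effect from one core to the other. The two pairs point in opposite directions, and the gap between them is too large to be set down to scatter: the same change on two cores in this assay, a number 35.2 percentage points lower (beyond the scatter) from compound 1 to compound 2 and a number 32.3 percentage points higher (beyond the scatter) from compound 3 to compound 4, 67.5 percentage points apart, beyond the scatter of two such steps. This shows that, in this series, the effect of the methyl depends on the core it sits on, but with one pair per core it does not show which feature of the two cores decides the direction, nor does it give a rule for any further core, and a reading at a single dose says nothing about potency.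

Open, from the compounds shown here alone, is how a larger group at the same amide-type nitrogen, such as ethyl, benzyl or a longer chain, would behave on each core, and whether any such step would follow the core in the same way. Also open, going by these compounds, is what the same methyl change would do on a core bearing chlorine or methoxy in place of the bromine or methyl groups.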